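A Dichlorophenyl Swap at the Limit of the Assay

The source may hold more compounds than are shown below. What is called first, only, known or untested is meant among the compounds shown, and "the series" means these compounds.

In a functional assay on SF-268 cells (Homo sapiens) for inhibition, read by sulforhodamine B assay, with a stated time of 48 h (on this read-out lower numbers stand for stronger inhibition of growth and higher numbers for weaker inhibition of growth), compound 3 (`COc1cccc(OC)c1/C=N/NC(=O)Cc1csc2nc(-c3ccc(Br)cc3)cn12`) gives > 100000 nM, a limit and not a number. Compound 1 (`O=C(Cc1csc2nc(-c3ccc(Br)cc3)cn12)N/N=C/c1ccccc1O`) gives > 100000 nM, also a limit. Compound 2 (`O=C(Cc1csc2nc(-c3ccc(Br)cc3)cn12)N/N=C/c1ccc(O)cc1`) gives > 100000 nM, again a limit.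

Compound 4 (`O=C(Cc1csc2nc(-c3ccc(Br)cc3)cn12)N/N=C/c1ccc(Cl)cc1Cl`) differs from compound 3 as follows: 2,4-dichlorophenyl in place of 2,6-dimethoxyphenyl on a carbon with a double bond to nitrogen. The bearing steps are a step that the two limits leave unreadable from compound 1 to compound 3, a step that the two limits leave unreadable from compound 2 to compound 3 and a step that the two limits leave unreadable from compound 1 to compound 2, so none offers a size to carry over. The evidence so far is the limit of > 100000 nM in this assay, at which 3 of the 3 values shown sit, and this keeps the expectation close to that limit, with no firm direction. The expected step is a number no higher from compound 3 to compound 4 (the limit leaves the size open), with only a modest chance of stronger inhibition of growth. Compound 4 is estimated at 100000 nM, in an expected range of 30000 nM to 200000 nM.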

Compound 4, concentration for total growth inhibition: > 100000 nM
Compound 4 ended at the assay's limit (the forecaster's own chance of this, stated with the estimate: 70%); the middle value lies on the limit itself.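

Compound 4 gives > 100000 nM and this is a limit, not a number. Its steps from compound 1, compound 2 and compound 3 cannot be read. In this assay the compounds shown leave open which group on this carbon, if any, would give a measurable value.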